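The source may hold more compounds than are shown below. What is called first, only, known or untested is meant among the compounds shown, and "the series" means these compounds.

In a functional assay on DU-145 cells (Homo sapiens) for cytotoxicity, read by CCK-8 assay and cell counting, with a stated time of 72 h (on this read-out higher numbers stand for weaker inhibition and lower numbers for stronger inhibition), three compounds have measured values.

Compound 1, `COc1ccc(-c2cc3ccccc3c(-c3ccc(O)cc3)n2)cc1`, gives > 50000 nM, which is a limit of the assay and not a number.
Compound 2, `COc1ccc(-c2cc3ccccc3c(-c3ccc(OC)cc3)n2)cc1`, gives > 50000 nM, likewise a limit.
Compound 3, `COc1cc(OC)cc(-c2cc3ccccc3c(-c3cccc(O)c3)n2)c1`, gives 3870 nM.

From compound 1 to compound 2 the change is methyl in place of hydrogen on an oxygen on an aromatic ring. The step that the two limits leave unreadable from compound 1 to compound 2 cannot be read, since the limit of > 50000 nM in this assay, at which 2 of the 3 values shown sit, covers both ends of it. Compound 3 carries a different core; how it differs from the core of compound 1 is not broken down here. Among the three, compound 3 is the only one with a number in this assay.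

Compound 4, `COc1cc(OC)cc(-c2cc3ccccc3c(-c3cccc(OC)c3)n2)c1`, has not been measured. It differs from compound 3 by methyl in place of hydrogen on an oxygen on an aromatic ring, the same change as from compound 1 to compound 2. Read one bond further out the change is from 3-hydroxyphenyl to 3-methoxyphenyl, where in the earlier pair it was from 4-hydroxyphenyl to 4-methoxyphenyl. The earlier pair gives no readable step to lean on, so the expected step of a 3.1-fold higher number from compound 3 to compound 4 (0.49 log units; beyond the scatter) rests only on compound 3 and its value 3870 nM, and is taken to be a loss. Compound 4 is estimated at 12000 nM, expected between 3000 nM and 50000 nM.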

Compound 4, half-maximal inhibitory concentration: > 50000 nM
Compound 4: only a limit was reported (the forecaster's own chance of this, stated with the estimate: 35%); middle value at least 4.1-fold (0.61 log units) from the limit.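

In this assay the change from 3-hydroxyphenyl to 3-methoxyphenyl comes with an at least 12-fold higher number from compound 3 to compound 4 (1.11 log units; beyond the scatter), a large loss on this core that lies beyond the scatter. The value of compound 4, > 50000 nM, is a limit of the assay and not a number, so the step has a lower bound but no known full size. The same methyl-for-hydrogen change on the core of compound 1, there from 4-hydroxyphenyl to 4-methoxyphenyl, cannot be read, so the series does not show whether the effect carries from one core to the other, since the floor of the readable range hides it: the limit of > 50000 nM in this assay, at which 3 of the 4 values shown sit.

The compounds shown leave open whether the loss in compound 4 is specific to methyl or would follow from any replacement of that hydrogen, as with a longer chain such as ethoxy on the same oxygen. They also leave open how an amine or a carboxylic acid in place of the hydroxy group of compound 3 would read.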